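This account rests on a few compounds, and the source may have more. Where it says the series, first, only, none or still open, it means among the compounds named here.

Working notes on the series. Compound 1 `O=C1C=C(NC2CCCCC2)C(=O)c2c1nc1n2[C@H]2OC[C@@H](O)[C@H]2OC1` and compound 3 `O=C1C(NC2CCCCC2)=CC(=O)c2c1nc1n2[C@H]2OC[C@@H](O)[C@H]2OC1` are built from the same atoms joined differently; the difference between the two cores is not broken down here. In a functional assay on HeLa cells (Homo sapiens) for inhibition, read by sulforhodamine B assay (a higher number here means a weaker inhibitor, a lower number a stronger inhibitor), compound 1 gives only a limit, > 16000 nM. Compound 3 likewise gives only a limit in this assay, > 16000 nM. Compound 2 `CCOc1ccccc1NC1=CC(=O)c2nc3n(c2C1=O)[C@H]1OC[C@@H](O)[C@H]1OC3` carries 2-ethoxyphenyl in place of cyclohexyl on an amine nitrogen, and in this assay compound 2 gives 6040 nM. That change produced an at least 2.6-fold lower number from compound 1 to compound 2 (0.42 log units; beyond the scatter); the true size of the step is open upward because compound 1 sits at the limit of > 16000 nM in this assay, at which 2 of the 3 values shown sit. Compound 4 `CCOc1ccccc1NC1=CC(=O)c2c(nc3n2[C@H]2OC[C@@H](O)[C@H]2OC3)C1=O` has not yet been measured in this assay. Going by the values given here, it differs from compound 3 by 2-ethoxyphenyl in place of cyclohexyl on an amine nitrogen, the same change as the one from compound 1 to compound 2, at the same place. On that basis a step of an at least 2.2-fold lower number from compound 3 to compound 4 (0.35 log units; beyond the scatter) is expected, resting on an at least 2.6-fold lower number from compound 1 to compound 2 (0.42 log units; beyond the scatter). Compound 4 is therefore estimated at 7000 nM in this assay, expected to fall between 2500 nM and 16000 nM, with some chance that only a limit is reported.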

Compound 4, half-maximal inhibitory concentration: 8300 nM
For compound 4 the middle estimate is 1.2-fold (0.07 log units) below the measured one, within the range that was stated.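

In this assay, 2-ethoxyphenyl in place of cyclohexyl on an amine nitrogen again replaces a limit with a measured number on the second core, giving an at least 1.9-fold lower number from compound 3 to compound 4 (0.28 log units; that floor lies within the scatter). The change therefore points the same way on both cores shown, although the floor on the second core does not by itself clear the scatter. This does not show that the step has the same size on both cores, nor that it is larger on either one: the same change on two cores in this assay, an at least 2.6-fold lower number (0.42 log units; beyond the scatter) from compound 1 to compound 2 and an at least 1.9-fold lower number (0.28 log units; that floor lies within the scatter) from compound 3 to compound 4; the limit leaves it open whether they differ. Both step sizes remain floors rather than measured sizes, and the cyclohexyl end of each pair is only a limit: the limit of > 16000 nM in this assay, at which 2 of the 4 values shown sit.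

The compounds shown leave open whether the lower numbers go with the aromatic ring or with the ethoxy group on it, and an unsubstituted phenyl on the same amine nitrogen would separate the two. Going by these compounds, how a longer alkoxy chain in place of the ethoxy would read on either core also remains open.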